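This account rests on a few compounds, and the source may have more. Where it says the series, first, only, none or still open, it means among the compounds named here.

In a functional assay on Jurkat cells (Homo sapiens) for cytotoxicity, read by luminescence and CellTiter-Glo, with a stated time of 3 days (a higher number here means a weaker inhibitor, a lower number a stronger inhibitor), compound 1 (`N#Cc1cc(Cl)ccc1NC(=O)c1ccc2cccnc2c1O`) gives 170 nM and compound 2 (`N#Cc1ccc(NC(=O)c2ccc3cccnc3c2O)cc1`) gives 180 nM. Compound 3 (`O=C(Nc1ccc(C(F)(F)F)cc1)c1ccc2cccnc2c1O`) gives 550 nM, the highest number of the three. Compound 4 (`O=C(Nc1ccc(Cl)cc1)c1ccc2cccnc2c1O`) has chloro in place of trifluoromethyl on an aromatic carbon, para to a large group: chloro in place of trifluoromethyl on an aromatic carbon. For the measured compounds named here, the one measured step at this place is a 3.1-fold higher number from compound 2 to compound 3 (0.49 log units; beyond the scatter), where trifluoromethyl replaced cyano, and it was modest. Compound 1 also carries chloro, but it differs from compound 3 in more than one place, so it offers no clean comparison. A small move toward a lower number is therefore expected, possibly lost in the scatter. The estimated step is a 1.4-fold lower number from compound 3 to compound 4 (0.16 log units; within the scatter). For compound 4 the expected value is 380 nM, with a range of 160 nM to 900 nM.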

Compound 4, half-maximal inhibitory concentration: 510 nM
Beside the measured number, compound 4's estimate is 1.3-fold (0.13 log units) below it; low and high end bracket the measured number.
By their numbers in this assay, from the lowest: compounds 1 and 2 (each within the scatter of the next); then compounds 4 and 3 (each within the scatter of the next).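

In this assay, trifluoromethyl and chloro on this aromatic carbon, para to a large group, cannot be told apart: the swap gives a 1.1-fold lower number from compound 3 to compound 4 (0.03 log units; within the scatter). Cyano is different, since chloro in its place gives a 2.8-fold higher number from compound 2 to compound 4 (0.45 log units; beyond the scatter), and hydrogen in place of the cyano of compound 1 gives a 3.0-fold higher number from compound 1 to compound 4 (0.48 log units; beyond the scatter), so in both pairs the compound with cyano has the lower number. No measurement here accounts for these steps. Going by these compounds, whether an amine or a carboxylic acid at this place would behave like cyano or like chloro remains open.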